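Compound 3 and the limit of the series

A few compounds are considered here, and "the series" means these few. Any claim that something is new, unique, unknown or untested is made for them only; others in the source may bear on it.

Read-out: a functional assay on Caco-2 cells (Homo sapiens) for antiproliferative activity, read by MTT assay, with a stated time of 48 h; on this read-out lower numbers stand for stronger inhibition and higher numbers for weaker inhibition
- compound 1 `CCn1c(C(=O)Nc2ccc(OC(F)(F)F)cc2)ccc1C(CC)(CC)c1ccc(OCCC(O)(CC)CC)c(C)c1`: > 50000 nM (a limit)
- compound 2 `CCC(C)C(NC(=O)c1ccc(C(CC)(CC)c2ccc(OCCC(O)(CC)CC)c(C)c2)n1CC)C(=O)OC`: > 50000 nM (a limit)

Compound 2 stands only as a limit, > 50000 nM, and gives no number in this assay. Compound 1 is also only a limit, > 50000 nM. The two share one reading: the limit of > 50000 nM in this assay, at which 2 of the 2 values shown sit.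

Compound 3 `CCOC(=O)CN(C)C(=O)c1ccc(C(CC)(CC)c2ccc(OCCC(O)(CC)CC)c(C)c2)n1CC` carries its change on a carbonyl carbon, where ((ethoxycarbonyl)methyl)(methyl)amino enters: a group of 8 heavy atoms (5 carbon, 1 nitrogen, 2 oxygen; no ring) in place of a group of 10 heavy atoms (7 carbon, 1 nitrogen, 2 oxygen; no ring), on a carbonyl carbon. The rest of the structure is that of compound 2.

Among the compounds with values here, the only measured step that bears on this change is a step that the two limits leave unreadable from compound 1 to compound 2. It gives no size to carry over, so no direction can be drawn from it. The expectation that the reading stays at the limit rests on compound 2 with its limit of > 50000 nM. The estimated step is a number no higher from compound 2 to compound 3 (the limit leaves the size open), with no direction expected beyond the scatter. For compound 3 the estimated value is 50000 nM, with an expected range from 25000 nM to 100000 nM.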

Compound 3, half-maximal inhibitory concentration: 30300 nM
Compound 3: middle estimate off by 1.7-fold (0.22 log units), on the high side, and the stated range covers the measured number.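

Within the data shown here, compound 3 gives the first actual number in this assay, 30300 nM, so the carbonyl carbon is the first place where a change yields a readable value rather than a limit. Against the two limits, the change on that carbonyl carbon amounts to an at least 1.6-fold lower number from compound 2 to compound 3 (0.21 log units; that floor lies within the scatter), and the replacement of (4-(trifluoromethoxy)phenyl)amino by ((ethoxycarbonyl)methyl)(methyl)amino amounts to an at least 1.6-fold lower number from compound 1 to compound 3 (0.21 log units; that floor lies within the scatter). With both floors inside the scatter, the result sets a measured value for the series but does not establish a gain in activity, and most of the series shown still gives no number: the limit of > 50000 nM in this assay, at which 2 of the 3 values shown sit.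

The entering group counts 0 hydrogen-bond donors against 1 in the group it replaces in compound 2, but the compounds shown do not separate that difference from the other differences between the two groups, and the true size of either step remains open behind the limits. Also open, as far as these compounds go, is whether the reading follows the ethyl ester, which a carboxylic acid in its place or a plain dimethylamino group on the carbonyl carbon would test.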